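The compounds below may be only part of what the source reports. "The series", "measured", "known", "first", "only" and "open" are said of these compounds alone.

Three close relatives of one small amide have been tested in a functional assay on A549 cells (Homo sapiens) for antiproliferative activity, read by MTT assay, with a stated time of 72 h; a lower number here means a stronger inhibitor, a higher number a weaker inhibitor. Compound 1 `O=C(Nc1ccccc1Cl)C(Cl)Cl` gives 50200 nM. Compound 2 `O=C(Nc1ccccc1Br)C(Cl)Cl` carries bromine where compound 1 carries chlorine, and compound 2 gives 37000 nM; the step of a 1.4-fold lower number from compound 1 to compound 2 (0.13 log units; within the scatter) lies within the scatter, so these two numbers cannot be told apart. Compound 3 `O=C(Nc1ccccc1[N+](=O)[O-])C(Cl)Cl` carries a nitro group in that place and gives 198000 nM, the highest of the three numbers. Because the steps of a 3.9-fold higher number from compound 1 to compound 3 (0.60 log units; beyond the scatter) and a 5.4-fold higher number from compound 2 to compound 3 (0.73 log units; beyond the scatter) both lie beyond the scatter, compound 3 is the weakest inhibitor of the three in this assay.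

Compound 4 `O=C(Nc1ccccc1NC(=O)C(Cl)Cl)C(Cl)Cl` is the structure to be measured next. The change from compound 3 to compound 4 is ((dichloromethyl)carbonyl)amino in place of nitro on an aromatic carbon. For the measured compounds named here, no measured step exchanges a nitro group for an amide, so the only guidance comes from the two steps in which the nitro group went with a higher number, namely a 3.9-fold higher number from compound 1 to compound 3 (0.60 log units; beyond the scatter) and a 5.4-fold higher number from compound 2 to compound 3 (0.73 log units; beyond the scatter), both of modest size. Taking the nitro group away again is therefore expected to bring a modest step toward a lower number, estimated as a 3.3-fold lower number from compound 3 to compound 4 (0.52 log units; beyond the scatter). Compound 4 is thus expected to give about 60000 nM in this assay, with a likely range from 15000 nM to 250000 nM.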

Compound 4, half-maximal inhibitory concentration: 131000 nM
Estimate against measurement, compound 4: 2.2-fold (0.34 log units) below; measured number inside the range.
By their numbers in this assay, from the lowest: compounds 2 and 1 (each within the scatter of the next); then compounds 4 and 3 (each within the scatter of the next).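

In this assay the swap at this place on the aromatic ring shows almost no effect, even though ((dichloromethyl)carbonyl)amino has 6 heavy atoms against 3 for nitro and brings a hydrogen-bond donor that nitro lacks (a 1.5-fold lower number from compound 3 to compound 4 (0.18 log units; within the scatter)). The numbers for compound 3 and compound 4 therefore cannot be told apart, so this position tolerates a clear change in group with no readable shift in the number. Against the halogens the new group does stand apart, going with a higher number than chloro (a 2.6-fold higher number from compound 1 to compound 4 (0.42 log units; beyond the scatter)) and than bromo (a 3.5-fold higher number from compound 2 to compound 4 (0.55 log units; beyond the scatter)), so among these four compounds both non-halogen groups sit on the weaker side of the two halogens.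

Nothing shown here gives a reason for these numbers. On these data alone, it remains open whether a small group with no halogen, such as an amino or a methyl group, would match chloro and bromo or fall with nitro and ((dichloromethyl)carbonyl)amino, and whether a shorter amide such as acetylamino would read any differently.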